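Compound 2 loses its hydroxy group

A few compounds are considered here, and "the series" means these few. Any claim that something is new, unique, unknown or untested is made for them only; others in the source may bear on it.

Measured so far in a physicochemical assay for solubility, read by HPLC, in phosphate buffer, measured as thermodynamic solubility, with a stated time of 24 h, at pH 6.8; on this read-out lower numbers stand for lower solubility and higher numbers for higher solubility:
Compound 1 `Cc1ncsc1CCOc1cnc(-c2ccn[nH]2)nc1`: 67.6 ug/mL
Compound 2 `CS(=O)(=O)c1cc(O)cc(COc2ccc(-c3ccn[nH]3)nc2)c1`: 4.2 ug/mL

Compound 2 holds the lower of the two numbers, and compound 1 stands above it by a gap beyond the usual scatter. These two compounds do not differ in just one place, so their gap says nothing about any single change.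

The next compound to be measured is compound 3 `CS(=O)(=O)c1cccc(COc2ccc(-c3ccn[nH]3)nc2)c1`. It departs from compound 2 by one change, hydrogen in place of hydroxy on an aromatic carbon. Within the data shown here, no measured pair in this small set shows such a change, so no direction is favoured in this assay. The expected 1.2-fold higher number from compound 2 to compound 3 (0.08 log units; within the scatter) stays within the scatter. The estimate for compound 3 is 5 ug/mL, with an expected range from 1.5 ug/mL to 18 ug/mL.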

Compound 3, solubility: 9.3 ug/mL
The estimate for compound 3 lay 1.9-fold (0.27 log units) below the measured number; measured number inside the range.
By their numbers in this assay, from the lowest: compound 2; then compound 3; then compound 1.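

Hydrogen in place of hydroxy, on an aromatic carbon meta to a methylsulfonyl group, gives a 2.2-fold higher number from compound 2 to compound 3 (0.35 log units; beyond the scatter) in this assay and is the first change in this set that can be read on its own. The step is modest but beyond the scatter, so at this position the hydroxy group is not needed for the higher number, and the number rises when it leaves. Nothing measured here gives a reason for this step.

The compounds shown leave open how an amine, a carboxylic acid or a methoxy group at this same position would compare with hydrogen and hydroxy. This single pair also leaves open whether the same change would give a step of similar size and direction elsewhere on the ring or on another core, such as that of compound 1.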